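This account rests on a few compounds, and the source may have more. Where it says the series, first, only, none or still open, it means among the compounds named here.

Measured compounds:
- compound 1, `CCN(Cc1ccccc1)C(=O)c1nn(-c2ccc(F)cc2)c(OC[C@@H](O)C[C@@H](O)CC(=O)O)c1C(C)C`: in an assay on microsomes from liver for inhibition of 3-hydroxy-3-methylglutaryl-coenzyme A reductase (Rattus norvegicus) (on this read-out lower numbers stand for stronger inhibition and higher numbers for weaker inhibition), compound 1 gives 14 nM
- compound 2, `CC(C)c1c(C(=O)NCc2ccc(Cl)cc2)nn(-c2ccc(F)cc2)c1OC[C@@H](O)C[C@@H](O)CC(=O)O`: compound 2 gives 6.7 nM

Among the measured compounds shown here, compound 2 holds the lowest of the two numbers in this assay; the only measured step, a 2.1-fold lower number from compound 1 to compound 2 (0.32 log units; beyond the scatter), separates it from compound 1 and is beyond the scatter.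

Compound 3, `CC(C)c1c(C(=O)NCc2cccc(Cl)c2)nn(-c2ccc(F)cc2)c1OC[C@@H](O)C[C@@H](O)CC(=O)O`, is the next compound of the series. It differs from compound 2 in a single place: 3-chlorophenyl in place of 4-chlorophenyl on a saturated chain carbon bound to an amide-type nitrogen. For the measured compounds named here, no measured step of this kind exists; the one step in hand, a 2.1-fold lower number from compound 1 to compound 2 (0.32 log units; beyond the scatter), replaces the whole group on the carbonyl carbon and so bears on this change only loosely. With the chlorophenyl ring kept and the amide-type nitrogen unchanged, no step beyond the scatter in this assay is expected: a 1.3-fold higher number from compound 2 to compound 3 (0.13 log units; within the scatter) is the estimated change. Compound 3 is thus expected at 9 nM, with a range from 4 nM to 25 nM.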

Compound 3, half-maximal inhibitory concentration: 5.4 nM
Estimate against measurement, compound 3: 1.7-fold (0.22 log units) above; low and high end bracket the measured number.
By their numbers in this assay, from the lowest: compounds 3 and 2 (each within the scatter of the next); then compound 1.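

In this assay the change to 3-chlorophenyl from 4-chlorophenyl on a saturated chain carbon bound to an amide-type nitrogen gives a 1.2-fold lower number from compound 2 to compound 3 (0.09 log units; within the scatter) and so shows no readable preference between these two chlorophenyl groups. The step away from the benzyl(ethyl)amino amide, seen so far only with the 4-chlorobenzyl group, also appears with the 3-chlorobenzyl group, as a 2.6-fold lower number from compound 1 to compound 3 (0.41 log units; beyond the scatter) in this series. No measurement offered here explains this outcome.

Still open, from the compounds shown here alone, is how 2-chlorophenyl, methoxyphenyl or unsubstituted phenyl at this place would read in this assay for this series. Also open, going by these compounds, is whether the benzyl(ethyl)amino step comes from the ethyl group or from the chlorine, which a (benzyl)amino amide or a chlorobenzyl(ethyl)amino amide would separate.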